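Removing the methoxy from the benzyl-type ether

The source may report more compounds than this note shows. Statements on the series, on what has been measured and on what is new or still open speak of the compounds shown alone.

Measured in an ADME assay on KB cells (Homo sapiens) for cytotoxicity; on this read-out higher numbers stand for an effect only at larger amounts of compound and lower numbers for an effect already at smaller amounts:
- compound 1 `CCOC(=O)N1[C@@H]2C=C[C@@](OC)(C(=O)c3c2cc(OC)c(OC)c3OCC)N1C(=O)OCC`: > 300 ug/mL (a limit)
- compound 2 `CCCOc1c(OC)c(OC)cc2c1C(=O)[C@]1(OC)C=C[C@H]2N(C(=O)OCC)N1C(=O)OCC`: > 300 ug/mL (a limit)
- compound 3 `CCOC(=O)N1[C@@H]2C=C[C@@](OC)(C(=O)c3c2cc(OC)c(OC)c3OCc2ccc(OC)cc2)N1C(=O)OCC`: 63.1 ug/mL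

Two of these entries are not numbers: the limit of > 300 ug/mL in this assay, at which 2 of the 3 values shown sit. Among the three, compound 3 gives the only number, 63.1 ug/mL, and it lies lowest on both measured steps: an at least 4.7-fold lower number from compound 1 to compound 3 (0.67 log units; beyond the scatter) and an at least 4.7-fold lower number from compound 2 to compound 3 (0.67 log units; beyond the scatter). Both steps bring in the 4-methoxyphenyl group in place of a small chain. The remaining step, a step that the two limits leave unreadable from compound 1 to compound 2, gives no usable size.

Compound 4 `CCOC(=O)N1[C@@H]2C=C[C@@](OC)(C(=O)c3c2cc(OC)c(OC)c3OCc2ccccc2)N1C(=O)OCC` is next: hydrogen in place of methoxy on an aromatic carbon. This is hydrogen in place of methoxy on an aromatic carbon, or 4-methoxybenzyl to benzyl. Among the measured compounds shown here, the aromatic ring stays, and no measured step isolates the methoxy. The two steps to compound 3 therefore bear on this change only indirectly, and the size they show is not carried over. The expected result is a 1.1-fold higher number from compound 3 to compound 4 (0.05 log units; within the scatter), with no shift beyond the scatter anticipated. For compound 4 the estimate is 70 ug/mL, with an expected range of 25 ug/mL to 200 ug/mL.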

Compound 4, concentration for half-maximal effect: 215 ug/mL
For compound 4 the middle estimate is 3.1-fold (0.49 log units) below the measured one; measured number outside the range, above it.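

In this assay, the methoxy on the aromatic ring carries weight of its own: a 3.4-fold higher number from compound 3 to compound 4 (0.53 log units; beyond the scatter). With the aromatic ring kept and the methoxy gone, the steps from the small chains give only floors: an at least 1.3-fold lower number from compound 2 to compound 4 (0.14 log units; that floor lies within the scatter), and an at least 1.3-fold lower number from compound 1 to compound 4 (0.14 log units; that floor lies within the scatter). Compound 1 and compound 2 each stand at a limit, so neither step has a readable size: the limit of > 300 ug/mL in this assay, at which 2 of the 4 values shown sit.

The compounds shown leave open whether this step is particular to methoxy or would also appear with another group on the same aromatic carbon, such as hydroxyl, chlorine or an amine. They also leave open how a longer chain in place of the ethyl or propyl ether would read against compound 4.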